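From 3-methylphenyl to 4-methylphenyl in the series

This account rests on a few compounds, and the source may have more. Where it says the series, first, only, none or still open, it means among the compounds named here.

In an ADME assay on HepG2 cells (Homo sapiens) for inhibition, read by fluorescence and resazurin assay, with a stated time of 72 h (a lower number here means a stronger inhibitor, a higher number a weaker inhibitor), compound 1 `Cc1cccc(Nc2ncc(C)c(Nc3ccc4nc[nH]c4c3)n2)c1` gives 6600 nM and compound 2 `Cc1cccc(Nc2nccc(Nc3ccc4cn[nH]c4c3)n2)c1` gives 15000 nM. Compound 2 thus holds the higher of the two numbers, a gap beyond the scatter. Compound 3 `Cc1ccc(Nc2nccc(Nc3ccc4cn[nH]c4c3)n2)cc1` has 4-methylphenyl in place of 3-methylphenyl on a nitrogen on an aromatic ring, with the same atoms joined differently: 4-methylphenyl in place of 3-methylphenyl on a nitrogen on an aromatic ring. Going by the values given here, no measured step shows this kind of change. The expected step is small, a 1.2-fold lower number from compound 2 to compound 3 (0.06 log units; within the scatter), and is not expected to lie beyond the scatter. For compound 3 the estimated value is 13000 nM, with an expected range of 5500 nM to 30000 nM.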

Compound 3, half-maximal inhibitory concentration: 18000 nM
Estimate against measurement, compound 3: 1.4-fold (0.14 log units) below; low and high end bracket the measured number.
By their numbers in this assay, from the lowest: compound 1; then compounds 2 and 3 (each within the scatter of the next).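

In this assay the change from 3-methylphenyl to 4-methylphenyl on a nitrogen on an aromatic ring gives a 1.2-fold higher number from compound 2 to compound 3 (0.08 log units; within the scatter) as the first step read at this position. Where the methyl sits on this phenyl ring therefore makes no difference beyond the scatter for this pair. No measurement available here bears on this result.

The step covers only these two methylphenyl groups and says nothing about other substituents on this ring. From the compounds shown here alone, whether an amine, a carboxylic acid or a longer chain in place of the methyl would give a step beyond the scatter remains open.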